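Replacing Benzyloxy with Dimethylamino on the Shared Core

The source may hold more compounds than are shown below. What is called first, only, known or untested is meant among the compounds shown, and "the series" means these compounds.

In an ADME assay on L6 cells (Rattus norvegicus) for cytotoxicity, read by resazurin assay, with a stated time of 72 h (a higher number here means a weaker inhibitor, a lower number a stronger inhibitor), compound 1 `COc1ccc(C(=O)NC(=O)c2ccccc2O)cc1` gives 39 ug/mL and compound 2 `O=C(NC(=O)c1ccccc1O)c1ccc(OCc2ccccc2)cc1` gives 64 ug/mL, so these two compounds cannot be told apart. Compound 3 `CN(C)c1ccc(C(=O)NC(=O)c2ccccc2O)cc1` has dimethylamino in place of benzyloxy on an aromatic carbon. Within the data shown here, only one measured step bears on this change, a 1.6-fold higher number from compound 1 to compound 2 (0.22 log units; within the scatter), and it also alters the group at this place. On that evidence, no step beyond the scatter is expected in this assay. The estimated step is a 1.4-fold lower number from compound 2 to compound 3 (0.15 log units; within the scatter). Compound 3 is expected at 45 ug/mL, with an estimated range of 18 ug/mL to 100 ug/mL.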

Compound 3, half-maximal inhibitory concentration: 54 ug/mL
Compound 3: middle estimate off by 1.2-fold (0.08 log units), on the low side, and the stated range covers the measured number.
By their numbers in this assay, from the lowest: compounds 1, 3 and 2 (each within the scatter of the next).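

Dimethylamino in place of benzyloxy gives a 1.2-fold lower number from compound 2 to compound 3 (0.07 log units; within the scatter) in this assay, and dimethylamino in place of methoxy gives a 1.4-fold higher number from compound 1 to compound 3 (0.14 log units; within the scatter), so neither change moves the number beyond the scatter. The earlier compounds shown here carried only oxygen-linked groups at this position, whereas compound 3 shows that a nitrogen-linked group also leaves the reading within the scatter. No measurement here offers an explanation for this result.

Still open, on these data alone, is whether a carboxylic acid or a longer chain at this position would leave the number within the scatter as well.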